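The source may report more compounds than this note shows. Statements on the series, on what has been measured and on what is new or still open speak of the compounds shown alone.

Working notes on the series, read in a functional assay on HCT-116 cells (Homo sapiens) for inhibition, read by CCK-8 assay, with a stated time of 72 h, tested at 8 uM; on this read-out lower numbers stand for less inhibition of growth and higher numbers for more inhibition of growth at the one concentration tested. Among the measured compounds shown here, compound 1 `Nc1ccccc1NC(=O)/C=C/c1ccc(CSc2cccc(F)c2)cc1` gives 3.22% and compound 2 `Cc1ccc(SCc2ccc(/C=C/C(=O)Nc3ccccc3N)cc2)cc1` gives 4.93%, so compound 2 stands within the scatter of compound 1, the only other measured compound. Next is compound 3 `Nc1ccccc1NC(=O)/C=C/c1ccc(CSc2ccc(F)cc2)cc1`, which differs from compound 2 as follows: fluoro in place of methyl on an aromatic carbon. This is fluoro in place of methyl on an aromatic carbon, para to a large group. For the measured compounds named here, the one measured step that bears on it is a number 1.7 percentage points higher from compound 1 to compound 2 (within the scatter), which also exchanges the group on the sulfur and stays within the scatter. On that single step, no change beyond the scatter is expected, in either direction. The estimated step is a number 0.9 percentage points lower from compound 2 to compound 3 (within the scatter). For compound 3 the expected value is 4%, with an estimated range of 0% to 12%.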

Compound 3, percent growth inhibition at one concentration: 20.2%
Compound 3: the middle estimate sits 16.2 percentage points below what was measured; the whole stated range lies below it.
By their numbers in this assay, from the lowest: compounds 1 and 2 (each within the scatter of the next); then compound 3.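

In this assay, among the compounds shown here, the group on the sulfur does move the number: fluoro in place of methyl on an aromatic carbon, para to a large group, gives the first step beyond the scatter (a number 15.3 percentage points higher from compound 2 to compound 3 (beyond the scatter)). Fluoro alone does not account for this, as the 4-fluorophenyl and 3-fluorophenyl groups on the sulfur also separate beyond the scatter (a number 17 percentage points higher from compound 1 to compound 3 (beyond the scatter)), and compound 1, despite its fluoro, stays within the scatter of compound 2. Nothing measured here bears on why this change raises the number.

Going by these compounds, whether the rise is specific to fluoro remains open: chloro, methoxy or an amino group on the same aromatic carbon would test this. An unsubstituted phenyl on the sulfur would show whether the 4-fluorophenyl group adds to the number or the 4-methylphenyl and 3-fluorophenyl groups take away from it.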